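Fluoro for ethoxy: compound 3 to compound 4

The source may hold more compounds than are shown below. What is called first, only, known or untested is meant among the compounds shown, and "the series" means these compounds.

In a physicochemical assay for lipophilicity, using the shake flask method, at pH 7.4 (a higher number here means a more lipophilic compound, a lower number a more polar compound), compound 1 `O=C(O)COc1ccc(NC(=O)COc2ccccc2)cc1F` gives -1.25 and compound 2 `CC(Oc1ccccc1)C(=O)Nc1ccc(OCC(=O)O)c(F)c1` gives -0.18. Compound 3 `CCOc1ccccc1OC(C)C(=O)Nc1ccc(OCC(=O)O)c(F)c1` has no number, with its result given as "not determined" (no result reported). Compound 4 `CC(Oc1ccccc1F)C(=O)Nc1ccc(OCC(=O)O)c(F)c1` differs from it as fluoro in place of ethoxy on an aromatic carbon, ortho to a large group.

Among the compounds with values here, the only measured step is a number 1.07 log units higher from compound 1 to compound 2 (beyond the scatter). It concerns a methyl that compound 3 and compound 4 both carry, not the site changing here, so its size does not transfer. Within the data shown here, no step from compound 3 can be sized. The nearest anchor is compound 2 at -0.18, and no shift beyond the scatter from it is expected. The expected value for compound 4 is 0, with an estimated range of -0.45 to 0.45.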

Compound 4, distribution coefficient: 0.07
Compound 4: middle estimate off by 0.07 log units, on the low side, and the stated range covers the measured number.
By their numbers in this assay, from the lowest: compound 1; then compounds 2 and 4 (each within the scatter of the next).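

In this assay, the added fluoro gives a number 0.25 log units higher from compound 2 to compound 4 (within the scatter), so this ring position, unlike the methyl site in the earlier step, shows no shift beyond the scatter with this change. The step from compound 3 to compound 4 cannot be read, as compound 3 has no number. No measurement available here bears on why fluoro leaves the reading within the scatter.

Still open, going by these compounds, is how ethoxy itself reads at this position in this assay. Also open, on these data alone, is whether an amine or a nitrile on the same aromatic carbon would move the number beyond the scatter.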